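The source may report more compounds than this note shows. Statements on the series, on what has been measured and on what is new or still open speak of the compounds shown alone.

Measured in an assay on isolated protein for inhibition of aldehyde dehydrogenase 1A1 (Homo sapiens), read by spectrophotometry, tested at 10 uM; a higher number here means more inhibition at the concentration tested (going by the name of the read-out), a lower number less inhibition:
- compound 1 `CC(C)=CCn1c(CN2CCN(C(=O)C3CC3)CC2)nc2ccccc21`: 74.3%
- compound 2 `CC(C)CCn1c(OC2CCN(C(=O)c3ccco3)CC2)nc2ccccc21`: 30.8%
- compound 3 `Cc1cccc(Cn2c(CN3CCN(C(=O)c4ccncc4)CC3)nc3ccccc32)c1`: 20.6%

Compound 1 gives the highest of the three numbers, and both others lie beyond the scatter below it. Compound 2 comes nearest, compound 3 furthest. Compound 4 `O=C(C1CC1)N1CCN(Cc2nc3ccccc3n2Cc2cccc(Cl)c2)CC1` has not been measured in this assay; it differs from compound 1 in one place, (3-chlorophenyl in place of 2-methylprop-1-en-1-yl on a saturated chain carbon bound to an aromatic nitrogen), that is, 3-methylbut-2-en-1-yl to 3-chlorobenzyl, with the rest of the structure kept. Going by the values given here, no measured pair isolates this change. Compound 3, which carries a benzyl-type group on the same position but a different amide, reads low, so a drop is expected in this assay. The expected step of a number 26.3 percentage points lower from compound 1 to compound 4 (beyond the scatter) is a loss beyond the scatter. For compound 4 the estimate is 48%, within 20% to 78%.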

Compound 4, a percentage reported as inhibition, at one concentration (the size of the read-out at that concentration, not a potency): 71.6%
Compound 4: middle estimate off by 23.6 percentage points, on the low side; the range from low to high includes it.
By their numbers in this assay, from the lowest: compound 3; then compound 2; then compounds 4 and 1 (each within the scatter of the next).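

In this assay, the step at this position, on a saturated chain carbon bound to an aromatic nitrogen, is a number 2.7 percentage points lower from compound 1 to compound 4 (within the scatter) with the rest of the structure kept. At this concentration, 3-methylbut-2-en-1-yl and 3-chlorobenzyl therefore cannot be told apart, so the position accepts an aromatic ring as well as an open chain with a double bond. Nothing on hand explains why the two groups read alike.

Whether the chlorine contributes remains open, since plain benzyl is not among the compounds shown. Also open, going by these compounds, is how a longer chain or a chain ending in an amine would read at this position.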